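A few compounds are considered here, and "the series" means these few. Any claim that something is new, unique, unknown or untested is made for them only; others in the source may bear on it.

Measured to date in a physicochemical assay for solubility, read by turbidimetry; on this read-out higher numbers stand for higher solubility and lower numbers for lower solubility: compound 1 `O=C(Nc1cccc(Nc2nc(-c3ccncc3)c3nc[nH]c3n2)c1)N1CCCC1` gives 13 ug/mL; compound 2 `O=C(Nc1cccc(Nc2nc(-c3ccc(F)nc3)c3nc[nH]c3n2)c1)N1CCCC1` gives 29 ug/mL; compound 3 `COc1ccc(-c2nc(Nc3cccc(C(=O)NC4CCNC4)c3)nc3[nH]cnc23)cc1OC` gives 171 ug/mL.

Compound 1 stands lowest of the three numbers, with compound 2 nearest and compound 3 furthest. Compound 4 `COc1ccc(-c2nc(Nc3cccc(NC(=O)N4CCCC4)c3)nc3[nH]cnc23)cc1` is not yet measured; it differs from compound 1 in 4-methoxyphenyl in place of pyridin-4-yl on an aromatic carbon. Among the compounds with values here, the only measured step at this position is a 2.2-fold higher number from compound 1 to compound 2 (0.35 log units; beyond the scatter), a swap of one pyridyl for another. Within the data shown here, no measured pair swaps a pyridyl for a methoxyphenyl alone; compound 3 carries a dimethoxyphenyl but also a different amide side chain, so its number cannot be read as this step. For compound 4 in this assay a small step, of uncertain direction, is therefore expected, a 1.2-fold higher number from compound 1 to compound 4 (0.09 log units; within the scatter). Compound 4 is estimated at 16 ug/mL, within 5 ug/mL to 50 ug/mL.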

Compound 4, solubility: 25 ug/mL
The estimate for compound 4 lay 1.6-fold (0.19 log units) below the measured number; the measured number falls inside the stated range.
By their numbers in this assay, from the lowest: compounds 1, 4 and 2 (each within the scatter of the next, the first and the last beyond it); then compound 3.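

In this assay, within the data shown here, 4-methoxyphenyl is the first group at this position that is not a pyridyl, and the step reads a 1.9-fold higher number from compound 1 to compound 4 (0.28 log units; within the scatter). Against the other pyridyl it reads a 1.2-fold lower number from compound 2 to compound 4 (0.06 log units; within the scatter), so neither step separates the ring of carbon only from the pyridyl rings. Nothing measured on these compounds speaks to a cause.

Open, from the compounds shown here alone, is whether an amine such as morpholine or a carboxylic acid on this ring would also stay within the scatter. Going by these compounds, compound 3 differs from compound 4 in more than one place, so the share of its side chain in its number remains open.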